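Swapping methoxy for chloro on a compound at the limit

The compounds below may be only part of what the source reports. "The series", "measured", "known", "first", "only" and "open" are said of these compounds alone.

In a functional assay on GC3/C1 cells (Homo sapiens) for cytotoxicity, read by MTT assay, with a stated time of 6 days (on this read-out higher numbers stand for weaker inhibition and lower numbers for stronger inhibition), compound 1 (`COc1ccc(NC(=O)SC[C@H](NC(C)=O)C(=O)O)cc1`) gives > 200000 nM as its result, and this is a limit of the assay, not a number. Compound 2 (`CC(=O)N[C@@H](CSC(=O)Nc1ccc(C(F)(F)F)cc1[N+](=O)[O-])C(=O)O`) also reaches only a limit (> 200000 nM) in this assay and has no exact number. The two results coincide (the limit of > 200000 nM in this assay, at which 2 of the 2 values shown sit), so compound 1 cannot be ranked against compound 2.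

Compound 3 (`CC(=O)N[C@@H](CSC(=O)Nc1ccc(Cl)cc1)C(=O)O`) has not yet been measured. It has chloro in place of methoxy on an aromatic carbon, para to a large group (chloro in place of methoxy on an aromatic carbon). Among the compounds with values here, no measured pair shows what this swap does. Within the data shown here, the only direct reference is compound 1 (> 200000 nM), which offers a limit rather than a number, so the forecast is uncertain. No step beyond the usual scatter is expected in this assay for this swap, and a result at the same limit is quite possible. The expected change (a number no higher from compound 1 to compound 3 (the limit leaves the size open)) is therefore small. The estimate for compound 3 is 200000 nM as the expected value, with an expected range (60000 nM to 400000 nM).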

Compound 3, half-maximal inhibitory concentration: 8130 nM
Estimate against measurement, compound 3: 25-fold (1.39 log units) above, and the stated range ends above it.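

In this assay, chloro in place of methoxy on an aromatic carbon, para to a large group, gives an at least 24-fold lower number from compound 1 to compound 3 (1.39 log units; beyond the scatter). Compound 3, at 8130 nM, has the only exact number among the compounds shown, so this swap at this place on the ring can move the read-out well beyond the usual scatter, a change that the earlier pair could not reveal. The full size of the step stays open on one side because compound 1 stands at a limit: the limit of > 200000 nM in this assay, at which 2 of the 3 values shown sit.

A single swap cannot tell whether chloro itself matters here or whether losing methoxy is enough, and a bromo, fluoro or methyl group at the same place, or a bare hydrogen, would help separate the two. Compound 2 differs from compound 3 in more than one place, so it cannot show which of its groups accounts for its limit, and the separate effects of trifluoromethyl and nitro on the ring remain unknown.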